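The source may hold more compounds than are shown below. What is called first, only, known or untested is meant among the compounds shown, and "the series" means these compounds.

Compound 1 `CCC(C)(C)Cc1c[nH]c(CCc2ccc(-n3ncnn3)cc2)n1`: 205 nM
Compound 2 `CCC(C)(C)Cc1c[nH]c(CCc2ccc(-c3cnsc3)cc2)n1`: 10 nM

Both numbers come from an in vitro assay on CHO cells for displacement of a labelled ligand from Bombesin receptor subtype-3 (Homo sapiens), read by scintillation counting, with a stated time of 2 h; a higher number here means a weaker inhibitor, a lower number a stronger inhibitor. Of the two measured compounds, compound 2 stands at the lower number, and the step from compound 1 to it, a 21-fold lower number from compound 1 to compound 2 (1.31 log units; beyond the scatter), is a large one, well beyond the usual scatter of this kind of measurement. Compound 3 `CCC(C)(C)Cc1c[nH]c(CCc2ccc(-c3cccc(C)n3)cc2)n1` has not yet been measured. It differs from compound 2 in one place: 6-methylpyridin-2-yl in place of 1,2-thiazol-4-yl on an aromatic carbon. Within the data shown here, the single measured step bears on this change only indirectly: it exchanged one ring for another at the same aromatic carbon and moved the number a long way, which shows that the group at this position can shift the result strongly, but it says nothing about a six-membered ring with one nitrogen at that spot. A step of real size in either direction is therefore plausible, and its direction cannot be read from the two measured compounds alone. Compound 3 is expected to give 30 nM, within a range of 8 nM to 150 nM, which means an estimated step of a 3.0-fold higher number from compound 2 to compound 3 (0.48 log units; beyond the scatter).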

Compound 3, half-maximal inhibitory concentration: 6.3 nM
Estimate against measurement, compound 3: 4.8-fold (0.68 log units) above; measured number below the stated range.
By their numbers in this assay, from the lowest: compounds 3 and 2 (each within the scatter of the next); then compound 1.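

In this assay, replacing 1,2-thiazol-4-yl with 6-methylpyridin-2-yl gives a 1.6-fold lower number from compound 2 to compound 3 (0.20 log units; within the scatter), so at this aromatic carbon a six-membered aromatic ring with 1 hetero atom and 7 heavy atoms reads the same as a five-membered aromatic ring with 2 hetero atoms and 5 heavy atoms. Replacing 2H-tetrazol-2-yl with the same group gives a 33-fold lower number from compound 1 to compound 3 (1.51 log units; beyond the scatter), which shows that the large gap first seen with compound 2 is not unique to the 1,2-thiazol-4-yl ring and leaves compound 1 alone at the high end of the three. Nothing measured here gives a reason for either result.

Going by these compounds, it remains open what the methyl group contributes, a question that would need a comparison with plain pyridin-2-yl on the same core. Also open, on these data alone, is whether a ring is needed at this carbon at all, and how a plain phenyl ring, a primary amine or a carboxylic acid there would read against compound 2 and compound 3.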